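The compounds below may be only part of what the source reports. "The series", "measured", "known", "first", "only" and "open" are said of these compounds alone.

For the measured compounds named here, compound 1 `Cn1c(-c2ccc(O)cc2)nc2c(NC3CCCC3)ncnc21` is one of three compounds measured in an assay on CHO cells for displacement of a labelled ligand from adenosine receptor A1 (Homo sapiens), read by scintillation counting, with a stated time of 3 h; a lower number here means a stronger inhibitor, a higher number a weaker inhibitor. Compound 1 gives 17 nM, the second highest of the three numbers. Its nearest neighbour is compound 3 `CCCn1c(-c2ccccc2)nc2c(NC3CCCCC3)ncnc21`, which gives 27 nM, and the furthest is compound 2 `CCn1c(-c2ccccc2)nc2c(NC3CCOC3)ncnc21`, which gives 10 nM; both gaps lie within the usual scatter, so the three cannot be told apart on these numbers. Compound 4 `Cn1c(-c2ccccc2Cl)nc2c(NC3CCCC3)ncnc21` has not been measured. It differs from compound 1 in one place: 2-chlorophenyl in place of 4-hydroxyphenyl on an aromatic carbon. Going by the values given here, no measured pair shows a change of this kind, so there is nothing to lean on. The step expected in this assay is small, a 1.5-fold higher number from compound 1 to compound 4 (0.17 log units; within the scatter), toward a weaker inhibitor and hardly beyond the scatter. Compound 4 is expected to give about 25 nM, with a likely range from 6 nM to 100 nM.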

Compound 4, inhibition constant: 37 nM
For compound 4 the middle estimate is 1.5-fold (0.17 log units) below the measured one; the range from low to high includes it.
By their numbers in this assay, from the lowest: compounds 2, 1, 3 and 4 (each within the scatter of the next, the first and the last beyond it).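

For the compounds shown here, replacing 4-hydroxyphenyl with 2-chlorophenyl on this aromatic carbon gives the first readable step in this assay: a 2.2-fold higher number from compound 1 to compound 4 (0.34 log units; beyond the scatter), a modest change. Compound 4 has no hydrogen-bond donor on this ring and still gives 37 nM, so the donor of compound 1 is not needed for a value in the nanomolar range. Nothing available explains the size of this step. Going by these compounds, the change removes the hydroxyl and adds the chlorine in one move, so their separate contributions remain unknown. On these data alone, a methoxy group or a carboxylic acid on this ring remains untested here.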